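The source may hold more compounds than are shown below. What is called first, only, known or untested is meant among the compounds shown, and "the series" means these compounds.

Measured in an ADME assay on WI-38 cells (Homo sapiens) for antiproliferative activity, read by sulforhodamine B assay, with a stated time of 72 h; on this read-out lower numbers stand for stronger inhibition and higher numbers for weaker inhibition:
- Compound 1 `C=CCOC(=O)C1=C2C(=NC1=O)c1cccc3c(SCCC)ccc2c13` gives 33200 nM
- Compound 2 `CCCSc1ccc2c3c(cccc13)C1=NC(=O)C(C(=O)OCC)=C12` gives 9600 nM
- Compound 3 `C=CCSc1ccc2c3c(cccc13)C1=NC(=O)C(C(=O)OCC(=O)SCCC)=C12` gives > 100000 nM (a limit, not a number)

Compound 3 therefore has no exact position on this scale, and its place is given by the limit of > 100000 nM in this assay, at which 1 of the 3 values shown sits. Compound 4 `CCCSC(=O)COC(=O)C1=C2C(=NC1=O)c1cccc3c(SCCC)ccc2c13` differs from it in a single place, with ethyl in place of vinyl on a saturated chain carbon bound to a sulfur, so that allylsulfanyl becomes propylsulfanyl (ethyl in place of vinyl on a saturated chain carbon bound to a sulfur).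

Among the measured compounds shown here, one measured step bears on this swap, though only loosely: a 3.5-fold lower number from compound 1 to compound 2 (0.54 log units; beyond the scatter). There, too, a vinyl leaves, but it gives way to methyl, and on a saturated chain carbon bound to an oxygen rather than a sulfur. That step was modest, so a modest move towards lower numbers is expected in this assay. The starting point is only a limit, which leaves the size of this move poorly fixed, and compound 4 may also reach the limit. The expected change is an at least 2.0-fold lower number from compound 3 to compound 4 (0.30 log units; that floor lies within the scatter). For compound 4 the estimated value is 50000 nM, with an expected range from 15000 nM to 100000 nM.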

Compound 4, half-maximal inhibitory concentration: > 100000 nM
Compound 4 gave a limit, no number; the forecaster's own chance of this, stated with the estimate: 40%; middle value at least 2.0-fold (0.30 log units) away from the limit.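

In this assay compound 3 and compound 4 each give a limit, not a number, so the step between them cannot be read. At a saturated chain carbon bound to an oxygen next to a carbonyl group, the change does register: (propylsulfanyl)carbonyl in place of methyl gives an at least 10-fold higher number from compound 2 to compound 4 (1.01 log units; beyond the scatter) and in place of vinyl gives an at least 3.0-fold higher number from compound 1 to compound 4 (0.47 log units; beyond the scatter) on the same scale. Going from allylsulfanyl to propylsulfanyl therefore does not bring this pair back to a readable number, and the set now stands as follows: the limit of > 100000 nM in this assay, at which 2 of the 4 values shown sit.

On these data alone, how much the allyl-to-propyl change matters stays open, since neither compound gives a number to compare. Also open, as far as these compounds go, is whether a carboxylic acid, an amide or a longer chain in place of the (propylsulfanyl)carbonyl group would give a readable value.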